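The compounds below may be only part of what the source reports. "The series", "measured", "known", "first", "only" and "open" are said of these compounds alone.

The measured compounds in an assay on HEK293 cells for displacement of a labelled ligand from metabotropic glutamate receptor 5 (Rattus norvegicus); a lower number here means a stronger inhibitor, a higher number a weaker inhibitor:

compound 1, `COc1cccc(C(=O)Nc2cc(-c3ccccc3)nn2-c2ccccc2)c1`, gives 1290 nM
compound 2, `O=C(Nc1cc(-c2ccccc2)nn1-c1ccccc1)c1cccc(C(F)(F)F)c1`, gives 1650 nM
compound 3, `COc1cc(OC)cc(C(=O)Nc2cc(-c3ccccc3)nn2-c2ccccc2)c1`, gives > 10000 nM, a limit of this assay and not a number

Compound 3 stands as the weakest of the three, its value being only a limit, (the limit of > 10000 nM in this assay, at which 1 of the 3 values shown sits). Compound 4, `O=C(Nc1cc(-c2ccccc2)nn1-c1ccccc1)c1ccc(Cl)c(Cl)c1`, differs from compound 3 in one place: 3,4-dichlorophenyl in place of 3,5-dimethoxyphenyl on a carbonyl carbon. Within the data shown here, two measured steps bear on this move, both running toward compound 3 rather than away from it: an at least 6.0-fold higher number from compound 2 to compound 3 (0.78 log units; beyond the scatter) and an at least 7.7-fold higher number from compound 1 to compound 3 (0.88 log units; beyond the scatter). Compound 4 carries on its phenyl two chlorines rather than the two methoxy groups of compound 3, so it resembles compound 2 more than compound 3 in kind, and a return to a measurable number in the region of compounds 1 and 2 is expected. Compound 4 is therefore estimated at 1500 nM, with a range from 500 nM to 6000 nM. That estimate means a step of an at least 6.6-fold lower number from compound 3 to compound 4 (0.82 log units; beyond the scatter).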

Compound 4, inhibition constant: 160 nM
Compound 4: middle estimate off by 9.4-fold (0.97 log units), on the high side; measured number below the stated range.
By their numbers in this assay, from the lowest: compound 4; then compounds 1 and 2 (each within the scatter of the next). At a limit, above all of these: compound 3.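

In this assay, the earlier compounds showed this position only holding its number or losing it; 3,4-dichlorophenyl on the carbonyl carbon is the first group shown to bring a gain, with a 10-fold lower number from compound 2 to compound 4 (1.01 log units; beyond the scatter) and an 8.1-fold lower number from compound 1 to compound 4 (0.91 log units; beyond the scatter). Exchanging 3,5-dimethoxyphenyl for this group gives an at least 62-fold lower number from compound 3 to compound 4 (1.79 log units; beyond the scatter). That step is only a bound, as compound 3 stands at a limit of the assay and not at a number: the limit of > 10000 nM in this assay, at which 1 of the 4 values shown sits.

The compounds shown leave open whether the gain follows the chlorines themselves or where they sit on the ring. A 3,5-dichlorophenyl or a 3,4-dimethoxyphenyl group at this carbonyl carbon would separate those two readings, and a single chlorine would show whether both chlorines are needed.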